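Swapping Dimethylamino for Bromo on an Anti-Inflammatory Ester

The compounds below may be only part of what the source reports. "The series", "measured", "known", "first", "only" and "open" are said of these compounds alone.

Compound 2 `CC(C)Cc1ccc(C(C)C(=O)Oc2ccc(/N=C/c3ccc(N(C)C)cc3)cc2)cc1` stands highest of the two compounds measured in a functional assay on the whole organism (strain Wistar CF) for inhibition, with Rattus norvegicus as the target, read by paw edema, with stated times of 1 h and 3 h, at a dose of 100 mg/kg by the oral route (a higher number here means more inhibition at the dose given (going by the name of the read-out), a lower number less inhibition), where compound 2 gives 104%. Within the data shown here, its only neighbour, compound 1 `COc1ccc(/C=N/c2ccc(OC(=O)C(C)c3ccc(CC(C)C)cc3)cc2)cc1`, gives 61.3% in this assay. Among the measured compounds shown here, the single measured step, a number 42.7 percentage points higher from compound 1 to compound 2 (beyond the scatter), shows that this position responds strongly. Compound 3 `CC(C)Cc1ccc(C(C)C(=O)Oc2ccc(/N=C/c3ccc(Br)cc3)cc2)cc1` differs from compound 2 in one place: bromo in place of dimethylamino on an aromatic carbon. For the measured compounds named here, no measured step involves bromo, so the size is uncertain. Because a number 42.7 percentage points higher from compound 1 to compound 2 (beyond the scatter) was large, a downward step is expected, a number 34 percentage points lower from compound 2 to compound 3 (beyond the scatter). Compound 3 is therefore estimated at 70%, within 45% to 100%.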

Compound 3, a percentage reported as inhibition, in the whole organism at one dose (the size of the read-out at that dose, not a potency): 44.7%
The estimate for compound 3 lay 25.3 percentage points above the measured number; measured number outside the range, below it.
By their numbers in this assay, from the lowest: compound 3; then compound 1; then compound 2.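

With a number 59.3 percentage points lower from compound 2 to compound 3 (beyond the scatter) and a number 16.6 percentage points lower from compound 1 to compound 3 (beyond the scatter) now in hand, bromo sits under both dimethylamino and methoxy, so this position can lower inhibition as well as raise it. At this aromatic carbon, the three groups rank dimethylamino, methoxy, then bromo, from most to least inhibition, with every gap beyond the scatter. Nothing available explains this order. Going by these compounds, whether an unsubstituted amine or a hydroxyl would match dimethylamino remains open, as does whether chloro or fluoro would give a number as low as bromo.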